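The source may report more compounds than this note shows. Statements on the series, on what has been measured and on what is new or still open speak of the compounds shown alone.

Compound 1 `COc1cc(OC)c2c(=O)c(OCC(=O)N/N=C/c3sccc3C)c(-c3cc(OC)c(OC)c(OC)c3)oc2c1`: 4470 nM
Compound 2 `COc1cc(OC)c2c(=O)c(OCCCCN3CCCC3)c(-c3cc(OC)c(OC)c(OC)c3)oc2c1`: 10400 nM
Compound 3 `CCN(CC)CCCCOc1c(-c2cc(OC)c(OC)c(OC)c2)oc2cc(OC)cc(OC)c2c1=O`: 13000 nM

In a functional assay on MDA-MB-231 cells (Homo sapiens) for cytotoxicity, read by MTT assay, with a stated time of 38 h (a lower number here means a stronger inhibitor, a higher number a weaker inhibitor), compound 3 stands at the high-number end of this small set, level with its nearest neighbour, and clearly apart from the furthest: a 2.9-fold higher number from compound 1 to compound 3 (0.46 log units; beyond the scatter). Compound 4 `COc1cc(OC)c2c(=O)c(OCCCCN3CCN(C)CC3)c(-c3cc(OC)c(OC)c(OC)c3)oc2c1` keeps the shared core and the chain, and the change is 4-methylpiperazin-1-yl in place of diethylamino on a saturated chain carbon, four bonds along the chain from an oxygen on an aromatic ring. The closest measured precedent is the exchange of pyrrolidin-1-yl for diethylamino: a 1.3-fold higher number from compound 2 to compound 3 (0.10 log units; within the scatter). The larger 2.3-fold higher number from compound 1 to compound 2 (0.37 log units; beyond the scatter) replaces a quite different side chain, so it bears less directly. Going by the values given here, no measured compound carries a six-membered ring here, which keeps the range wide. In this assay, the estimated change is none beyond the scatter, a 1.2-fold lower number from compound 3 to compound 4 (0.07 log units; within the scatter). Compound 4 is expected at 11000 nM, with an estimated range of 5000 nM to 24000 nM.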

Compound 4, half-maximal inhibitory concentration: 3870 nM
For compound 4 the middle estimate is 2.8-fold (0.45 log units) above the measured one, outside the stated range (below it).
By their numbers in this assay, from the lowest: compounds 4 and 1 (each within the scatter of the next); then compounds 2 and 3 (each within the scatter of the next).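

In this assay this position proves sensitive to the amine after all: 4-methylpiperazin-1-yl gives a 3.4-fold lower number from compound 3 to compound 4 (0.53 log units; beyond the scatter) and a 2.7-fold lower number from compound 2 to compound 4 (0.43 log units; beyond the scatter), whereas exchanging pyrrolidin-1-yl for diethylamino stayed within the scatter. The amine alone also brings the chain level with the quite different side chain of compound 1 (a 1.2-fold lower number from compound 1 to compound 4 (0.06 log units; within the scatter)). No measured evidence here accounts for the step.

Going by these compounds, whether it follows the ring, the added nitrogen or its methyl stays open; piperidin-1-yl, morpholin-4-yl or unsubstituted piperazin-1-yl would separate these. On these data alone, whether 4-methylpiperazin-1-yl on a shorter chain behaves alike is also open.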